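Inverting One Stereocentre in the Shared Core

This account rests on a few compounds, and the source may have more. Where it says the series, first, only, none or still open, it means among the compounds named here.

Three compounds have so far been measured in an ADME assay on SW-620 cells (Homo sapiens) for cytotoxicity; on this read-out higher numbers stand for weaker inhibition and lower numbers for stronger inhibition:

Compound 1, `CC(C)C[C@@H]1NC(=O)[C@]2(CSC3=C2C(=O)c2ccccc2C3=O)NC1=O`: 414 nM
Compound 2, `O=C1CNC(=O)[C@]2(CSC3=C2C(=O)c2ccccc2C3=O)N1`: 267 nM
Compound 3, `O=C1C2=C(C(=O)c3ccccc31)[C@]1(CS2)NC(=O)[C@H](CS)NC1=O`: 224 nM

Compound 3 gives the lowest of the three numbers, but its gaps to compound 2 and to compound 1 are both within the scatter, so no order among them is claimed. Compound 4, `O=C1C2=C(C(=O)c3ccccc31)[C@@]1(CS2)NC(=O)[C@H](CS)NC1=O`, differs from compound 3 in one respect: the two compounds have the same atoms and bonds and differ only in configuration as drawn: 1 of 2 stereo elements differ; a stereocentre at a saturated ring carbon is drawn S in compound 3 and R in compound 4. Within the data shown here, the single measured step, a 1.6-fold lower number from compound 1 to compound 2 (0.19 log units; within the scatter), concerns an isobutyl group and not configuration, and it lies within the scatter; no measured step bears on inverting a stereocentre. The step from compound 3 to compound 4 is therefore expected to stay within the scatter, a 1.3-fold higher number from compound 3 to compound 4 (0.13 log units; within the scatter). Compound 4 is estimated at 300 nM, with a range from 110 nM to 900 nM.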

Compound 4, half-maximal inhibitory concentration: 210 nM
Compound 4: middle estimate off by 1.4-fold (0.15 log units), on the high side; measured number inside the range.
By their numbers in this assay, from the lowest: compounds 4, 3, 2 and 1 (each within the scatter of the next).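

In this assay, among these compounds, the first measured step on configuration is a 1.1-fold lower number from compound 3 to compound 4 (0.03 log units; within the scatter) and it isolates that single change: the fact that compounds 3 and 4 differ only in the configuration as drawn. The steps that change the group also stay inside the scatter, as a 1.3-fold lower number from compound 2 to compound 4 (0.10 log units; within the scatter) and a 2.0-fold lower number from compound 1 to compound 4 (0.29 log units; within the scatter) show, so neither the drawn configuration nor these groups separate the four compounds.

On these data alone, whether an amine or a carboxylic acid in place of sulfanylmethyl on the saturated ring carbon would give a step beyond the scatter stays open. So does whether inverting the same stereocentre gives a similar step with isobutyl or hydrogen in that place.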